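Methyl Added to the Anilino Ring of Compound 2

This account rests on a few compounds, and the source may have more. Where it says the series, first, only, none or still open, it means among the compounds named here.

Measured compounds:
- compound 1 `O=C1CCC(N2C(=O)c3ccc(Nc4ccccc4)cc3C2=O)C(=O)N1`: 6%
- compound 2 `O=C1CCC(N2C(=O)c3cccc(Nc4ccccc4)c3C2=O)C(=O)N1`: 4%
- compound 3 `Cc1ccc(Nc2ccc3c(c2)C(=O)N(C2CCC(=O)NC2=O)C3=O)cc1`: 5%

Of the compounds shown here, three have been tested in an assay on FRT-Jurkat cells for inhibition of nuclear factor NF-kappa-B complex (Homo sapiens), read by flow cytometry, with a stated time of 24 h, tested at 10 uM; on this read-out lower numbers stand for less inhibition and higher numbers for more inhibition at the one concentration tested (going by the name of the read-out). Compound 1 `O=C1CCC(N2C(=O)c3ccc(Nc4ccccc4)cc3C2=O)C(=O)N1` gives 6%, compound 2 `O=C1CCC(N2C(=O)c3cccc(Nc4ccccc4)c3C2=O)C(=O)N1` gives 4%, and compound 3 `Cc1ccc(Nc2ccc3c(c2)C(=O)N(C2CCC(=O)NC2=O)C3=O)cc1` gives 5%. All three numbers are small and lie within the scatter of one another, so none of the compounds can be set apart from the others. Compound 2 holds the lowest number, but only by a margin that repeated measurements would blur.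

The new compound, compound 4 `Cc1ccc(Nc2cccc3c2C(=O)N(C2CCC(=O)NC2=O)C3=O)cc1`, differs from compound 2 by methyl in place of hydrogen on an aromatic carbon. One measured step speaks to this change: a number 1 percentage points lower from compound 1 to compound 3 (within the scatter), on a core where the anilino group sits at a different position. That step stayed within the scatter. Compound 4 is therefore expected to remain close to compound 2, with a step of no change at the digits printed from compound 2 to compound 4 (within the scatter) that should not exceed the scatter. The estimate for compound 4 in this assay is 4%, with a range from -5% to 13%.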

Compound 4, a percentage reported as inhibition, at one concentration (the size of the read-out at that concentration, not a potency): 9%
The estimate for compound 4 lay 5 percentage points below the measured number; the measured number falls inside the stated range.
By their numbers in this assay, from the lowest: compounds 2, 3, 1 and 4 (each within the scatter of the next).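

Going from phenyl to 4-methylphenyl on the core of compound 2 gives, in this assay, a number 5 percentage points higher from compound 2 to compound 4 (within the scatter). The methyl, para to a large group, therefore leaves the number on this second core within what repeated measurements would give, and all four compounds stay small numbers that cannot be told apart. The change now has a reading on two cores, and those readings cannot be separated either: the same change on two cores in this assay, a number 1 percentage points lower (within the scatter) from compound 1 to compound 3 and a number 5 percentage points higher (within the scatter) from compound 2 to compound 4, 6 percentage points apart, within the scatter of two such steps

The compounds shown carry only hydrogen or methyl at this place, so it remains open whether a different group there, such as an amine, a carboxylic acid or a longer chain, would move the number beyond the scatter. From the compounds shown here alone, with a reading at only one concentration, potency also remains open.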